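A few compounds are considered here, and "the series" means these few. Any claim that something is new, unique, unknown or untested is made for them only; others in the source may bear on it.

The measured compounds in an assay on microsomes from liver for inhibition of acyl-CoA desaturase 1 (Rattus norvegicus) (on this read-out lower numbers stand for stronger inhibition and higher numbers for weaker inhibition), are:

compound 1 `Cc1cccc(OC2CCN(c3ccc(-n4ccnc4)nn3)CC2)c1`, 251 nM
compound 2 `Brc1cccc(OC2CCN(c3ccc(-n4ccnc4)nn3)CC2)c1`, 23 nM
compound 3 `c1cn(-c2ccc(N3CCC(Oc4ccc5c(c4)CCC5)CC3)nn2)cn1`, 62 nM

Among these three, compound 3 stands second highest. Compound 2 sits nearest to it, with a 2.7-fold higher number from compound 2 to compound 3 (0.43 log units; beyond the scatter) separating the two, and compound 1 furthest, with a 4.0-fold lower number from compound 1 to compound 3 (0.61 log units; beyond the scatter).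

Compound 4 `Brc1ccccc1OC1CCN(c2ccc(-n3ccnc3)nn2)CC1` has not yet been measured in this assay. Its change from compound 3 is 2-bromophenyl in place of 2,3-dihydro-1H-inden-5-yl on an oxygen on a saturated carbon. Among the compounds with values here, two measured steps bear on this. a 2.7-fold higher number from compound 2 to compound 3 (0.43 log units; beyond the scatter) shows that exchanging a bromophenyl for the 2,3-dihydro-1H-inden-5-yl group raised the number by a modest amount, so a return to a bromophenyl may be expected to lower it again. an 11-fold lower number from compound 1 to compound 2 (1.04 log units; beyond the scatter) shows a large lowering when bromo replaced methyl on an aromatic carbon. Within the data shown here, neither step, however, involves 2-bromophenyl itself: the bromophenyl measured so far is 3-bromophenyl, and no measured pair tells how much that difference in name matters. A modest lowering is therefore expected for compound 4, a 1.6-fold lower number from compound 3 to compound 4 (0.19 log units; within the scatter), with wide uncertainty. Compound 4 is estimated at 40 nM in this assay, within a range from 12 nM to 130 nM.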

Compound 4, half-maximal inhibitory concentration: 5 nM
Beside the measured number, compound 4's estimate is 8.0-fold (0.90 log units) above it, and the stated range ends above it.
By their numbers in this assay, from the lowest: compound 4; then compound 2; then compound 3; then compound 1.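

In this assay, within the data shown here, the place of the bromine on the phenyl group proves to matter: 2-bromophenyl in place of 3-bromophenyl gives a 4.6-fold lower number from compound 2 to compound 4 (0.66 log units; beyond the scatter), a difference that no earlier pair could size. On this oxygen on a saturated carbon, 2-bromophenyl also outdoes the 2,3-dihydro-1H-inden-5-yl group, with a 12-fold lower number from compound 3 to compound 4 (1.09 log units; beyond the scatter), and the 3-methylphenyl group, with a 50-fold lower number from compound 1 to compound 4 (1.70 log units; beyond the scatter), so this group gives the lowest number of the four. No measurement given here accounts for these steps.

The compounds shown leave open whether the gain belongs to bromine itself or would also appear with 2-chlorophenyl or 2-methylphenyl. They also leave open whether the phenyl group at this position would tolerate an amine or a carboxylic acid alongside the bromine.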